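Cyano in place of fluoro on an aromatic carbon

The compounds below may be only part of what the source reports. "The series", "measured", "known", "first", "only" and "open" are said of these compounds alone.

Measured so far in a functional assay on MCF7 cells (Homo sapiens) for antiproliferative activity, read by CellTiter-Glo, with a stated time of 5 days (a lower number here means a stronger inhibitor, a higher number a weaker inhibitor), with these values
compound 1 `O=C(O)/C=C/c1ccc(/C(=C(\c2ccccc2)C2CCC2)c2ccc3scnc3c2)cc1` gives 16 nM
compound 2 `O=C(O)/C=C/c1ccc(/C(=C(\c2ccc(F)cc2Cl)C2CCC2)c2ccc3scnc3c2)cc1` gives 3 nM

Of these two numbers, compound 2 holds the lower one, 3 nM in this assay and so stands as the reference for the next comparison. Compound 3 `N#Cc1ccc(/C(=C(\c2ccc(/C=C/C(=O)O)cc2)c2ccc3scnc3c2)C2CCC2)c(Cl)c1` turns 2-chloro-4-fluorophenyl into 2-chloro-4-cyanophenyl, with cyano in place of fluoro on an aromatic carbon, para to a large group and meta to a chloro group (cyano in place of fluoro on an aromatic carbon). Among the compounds with values here, only one measured step bears on this change (a 5.3-fold lower number from compound 1 to compound 2 (0.73 log units; beyond the scatter)). That modest step, beyond the scatter, brought in the chloro and fluoro groups together, so it does not isolate the fluoro group. Within the data shown here, no measured pair changes that group alone, and no cyano compound has a value yet. A smaller step than that one is therefore expected, with a slight rise in the number and no shift beyond the scatter. The estimated change is a 1.7-fold higher number from compound 2 to compound 3 (0.22 log units; within the scatter) and remains uncertain in direction. For compound 3 the estimated value is 5 nM (1.5 nM to 16 nM).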

Compound 3, half-maximal inhibitory concentration: 1.4 nM
Compound 3: the middle estimate sits 3.6-fold (0.55 log units) above what was measured, outside the stated range (below it).
By their numbers in this assay, from the lowest: compound 3; then compound 2; then compound 1.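

In this assay, within the data shown here, cyano in place of fluoro on an aromatic carbon, para to a large group and meta to a chloro group, gives a 2.1-fold lower number from compound 2 to compound 3 (0.33 log units; beyond the scatter) and is the first step that changes this position alone. The earlier step brought in the chloro and fluoro groups together, whereas this one shows that the position itself still affects the number once the chloro group is in place, and that the larger cyano group, with its hydrogen-bond acceptor, is accepted here. Relative to plain phenyl, 2-chloro-4-cyanophenyl gives an 11-fold lower number from compound 1 to compound 3 (1.06 log units; beyond the scatter) and so reaches a large step, where 2-chloro-4-fluorophenyl gave the modest 5.3-fold lower number from compound 1 to compound 2 (0.73 log units; beyond the scatter) on the same shared core.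

Nothing available on these compounds accounts for the lower number with cyano.

The compounds shown leave open the separate share of the chloro group, which changes here only together with the fluoro or cyano group. Also open, going by these compounds, is how this position responds to other groups, such as an amine, a methoxy group, trifluoromethyl or a longer chain, and whether the order of fluoro and cyano holds on a different core.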